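Shortening the alkylamino chain: compound 2 to compound 3

This account rests on a few compounds, and the source may have more. Where it says the series, first, only, none or still open, it means among the compounds named here.

Compound 1 `CCCCNc1nnc(SCC(=O)N(Cc2cccc([N+](=O)[O-])c2)c2ccc(F)cc2)s1` and compound 2 `CC(C)Nc1nnc(SCC(=O)N(Cc2cccc([N+](=O)[O-])c2)c2ccc(F)cc2)s1` share one core and differ only in the chain on the ring nitrogen. In an assay on isolated protein for inhibition of Amine oxidase [flavin-containing] A (Homo sapiens), read by fluorescence and Amplex Red, with a stated time of 30 min, tested at 0.1 uM (a lower number here means a weaker effect, a higher number a stronger effect of the compound at the concentration tested), compound 1 gives 33.6%. Going by the values given here, in the same assay compound 2 gives 43%, the sole other number of the pair, and the step of a number 9.4 percentage points higher from compound 1 to compound 2 (within the scatter) does not leave the scatter, so no order between the two can be read. Compound 3 `CCNc1nnc(SCC(=O)N(Cc2cccc([N+](=O)[O-])c2)c2ccc(F)cc2)s1` carries the change (hydrogen in place of methyl on a saturated chain carbon bound to a nitrogen on an aromatic ring and a saturated chain carbon). Among the compounds with values here, the only measured step that bears on it is the butyl-to-isopropyl one, and that was small, so for compound 3 the expected step in this assay is a number 3 percentage points lower from compound 2 to compound 3 (within the scatter), nothing beyond the scatter. Compound 3 is therefore estimated at 40%, within 25% to 55%.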

Compound 3, a percentage reported as inhibition, at one concentration (the size of the read-out at that concentration, not a potency): 42.1%
Beside the measured number, compound 3's estimate is 2.1 percentage points below it, within the range that was stated.
By their numbers in this assay, from the lowest: compounds 1, 3 and 2 (each within the scatter of the next).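

The ethylamino chain joins butylamino and isopropylamino on the shared core, and in this assay the read-out shows a number 0.9 percentage points lower from compound 2 to compound 3 (within the scatter) and a number 8.5 percentage points higher from compound 1 to compound 3 (within the scatter). Across these chains on the nitrogen, no order can be read, and neither swap moves the read-out beyond the scatter at this single concentration. Nothing available explains these numbers.

Going by these compounds, whether a hexyl chain or an unsubstituted amino group at this place would move the read-out beyond the scatter stays open. So does whether these three chains would separate at another concentration.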